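A few compounds are considered here, and "the series" means these few. Any claim that something is new, unique, unknown or untested is made for them only; others in the source may bear on it.

In a functional assay on CAKI-1 cells (Homo sapiens) for inhibition, read by sulforhodamine B assay, with a stated time of 48 h (a lower number here means a stronger inhibitor of growth, a higher number a weaker inhibitor of growth), compound 3 `Nc1cc(N)c2nc(-c3ccccc3)c(NCc3ccc(Cl)c(Cl)c3)nc2c1` gives 13200 nM, the lowest of the two numbers in this set. Compound 1 `Nc1cc(N)c2nc(-c3ccccc3)c(Oc3ccc(Cl)c(Cl)c3)nc2c1` gives 15800 nM in this assay, and the values of compound 3 and compound 1 sit within the scatter of each other, so neither can be set apart from the other. Compound 2 `CCOC(=O)[C@H](CCC(=O)O)NC(=O)c1ccc(CNc2nc3cc(N)cc(N)c3nc2-c2ccccc2)cc1` reaches only a limit in this assay, < 100000 nM, which is not a number (the limit of < 100000 nM in this assay, at which 1 of the 3 values shown sits). Compound 4 `COc1ccc(CNc2nc3cc(N)cc(N)c3nc2-c2ccccc2)cc1OC` has not yet been measured in this assay. It differs from compound 3 in one place: 3,4-dimethoxyphenyl in place of 3,4-dichlorophenyl on a saturated chain carbon bound to a nitrogen on an aromatic ring. Among the compounds with values here, no pair of measured compounds in this set is joined by such a change, so the direction and size of the step from compound 3 to compound 4 in this assay cannot be read from any measured pair. The expectation is a modest step toward a higher number, of the size a 1.9-fold higher number from compound 3 to compound 4 (0.28 log units; within the scatter), though a step within the scatter, or none at all, would not be surprising. For compound 4 in this assay the estimate is 25000 nM, with a range from 8000 nM to 80000 nM.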

Compound 4, concentration for 50% growth inhibition: 11200 nM
Beside the measured number, compound 4's estimate is 2.2-fold (0.35 log units) above it; the range from low to high includes it.
By their numbers in this assay, from the lowest: compounds 4, 3 and 1 (each within the scatter of the next).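

In this assay, the first step measured at this place, 3,4-dimethoxyphenyl in place of 3,4-dichlorophenyl on a saturated chain carbon bound to a nitrogen on an aromatic ring, gives a 1.2-fold lower number from compound 3 to compound 4 (0.07 log units; within the scatter). At this place, then, a group of 10 heavy atoms with 2 hydrogen-bond acceptors and a group of 8 heavy atoms with none cannot be told apart in growth inhibition, so the exchange of the two chlorines for two methoxy groups leaves the read-out unresolved from the scatter. No measurement shown here bears on why the two compounds cannot be set apart.

What the compounds shown leave open is whether this tolerance extends to groups of another kind on the same chain carbon, such as a phenyl ring carrying an amine or a carboxylic acid, or a longer chain between the ring and the nitrogen. From the compounds shown here alone, it also remains open whether the same exchange of 3,4-dichlorophenyl for 3,4-dimethoxyphenyl would give a step within the scatter on the oxygen-linked compound 1.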